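The source may report more compounds than this note shows. Statements on the series, on what has been measured and on what is new or still open speak of the compounds shown alone.

For the measured compounds named here, in a functional assay on B16-F0 cells (Mus musculus) for inhibition, read by CCK-8 assay, with a stated time of 48 h (on this read-out lower numbers stand for stronger inhibition and higher numbers for weaker inhibition), compound 3 `COc1ccc(-c2cc3nccc(-c4cc(OC)c(OC)c(OC)c4)n3n2)cc1` gives 1410 nM, the second highest of the three numbers measured so far. Compound 1 `COc1cc(-c2ccnc3cc(-c4ccc5ccn(C)c5c4)nn23)cc(OC)c1OC` gives 657 nM, and compound 2 `COc1cc(-c2ccnc3cc(-c4ccccc4)nn23)cc(OC)c1OC` gives 4730 nM. Against compound 1 the step is a 2.1-fold higher number from compound 1 to compound 3 (0.33 log units; beyond the scatter); against compound 2 it is a 3.4-fold lower number from compound 2 to compound 3 (0.53 log units; beyond the scatter); and the step of a 7.2-fold higher number from compound 1 to compound 2 (0.86 log units; beyond the scatter) spans the whole set.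

Compound 4 `COc1cc(-c2ccnc3cc(-c4cccc(C)c4)nn23)cc(OC)c1OC` has not yet been measured. It differs from compound 3 in one place: 3-methylphenyl in place of 4-methoxyphenyl on an aromatic carbon. The nearest guide is the step of a 3.4-fold lower number from compound 2 to compound 3 (0.53 log units; beyond the scatter), which shows that compound 2, lacking the methoxy, gave the higher number. Going by the values given here, in compound 4 the methoxy is also gone, but 3-methylphenyl enters instead of a bare phenyl, and no measured pair shows what that methyl alone does here. The expected step is therefore a rise in this assay, short of a full return to the number of compound 2, a 2.1-fold higher number from compound 3 to compound 4 (0.33 log units; beyond the scatter). Compound 4 is expected to give about 3000 nM, in a range from 1200 nM to 7000 nM.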

Compound 4, half-maximal inhibitory concentration: 2220 nM
Compound 4: middle estimate off by 1.4-fold (0.13 log units), on the high side, within the range that was stated.
By their numbers in this assay, from the lowest: compound 1; then compounds 3 and 4 (each within the scatter of the next); then compound 2.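

Replacing 4-methoxyphenyl with 3-methylphenyl at this position gives a 1.6-fold higher number from compound 3 to compound 4 (0.20 log units; within the scatter) in this assay, so the two groups cannot be told apart here. For the compounds shown here, the methyl effect, which no earlier pair could show, appears as a 2.1-fold lower number from compound 2 to compound 4 (0.33 log units; beyond the scatter) and means that a methoxy is not the only small group on the phenyl ring that gives a lower number than the bare phenyl of compound 2. The 1-methyl-1H-indol-6-yl group keeps its lead over this new group, as a 3.4-fold higher number from compound 1 to compound 4 (0.53 log units; beyond the scatter) shows, so the two-ring group remains the best of those compared with 3-methylphenyl.

Still open, on these data alone, is how an amine, a carboxylic acid or a longer chain such as ethoxy on the phenyl ring would behave at this position. Nothing available explains why any of these groups gives the number it does.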